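A few compounds are considered here, and "the series" means these few. Any claim that something is new, unique, unknown or untested is made for them only; others in the source may bear on it.

Measured so far in an assay on isolated protein for binding affinity to Equilibrative nucleoside transporter 1 (Homo sapiens); on this read-out higher numbers stand for weaker inhibition and lower numbers for stronger inhibition:
Compound 1 `OC[C@H]1O[C@@H](n2cnc3c(OCc4ccccc4)ncnc32)[C@H](O)[C@@H]1O` gives 2090 nM in this assay.
Compound 2 `OC[C@H]1O[C@@H](n2cnc3c(SC4CCCCC4)ncnc32)[C@H](O)[C@@H]1O` gives 6310 nM in this assay.
Compound 3 `OC[C@H]1O[C@@H](n2cnc3c(CSc4ccccc4Cl)ncnc32)[C@H](O)[C@@H]1O` gives 1780 nM in this assay.

Compound 3 has the lowest of the three numbers, but its standing is mixed: the step of a 1.2-fold lower number from compound 1 to compound 3 (0.07 log units; within the scatter) is within the scatter, so compound 1 and compound 3 cannot be told apart, whereas the step of a 3.5-fold lower number from compound 2 to compound 3 (0.55 log units; beyond the scatter) sets compound 2 clearly apart with the weaker result. The third measured step, a 3.0-fold higher number from compound 1 to compound 2 (0.48 log units; beyond the scatter), is of similar modest size.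

Compound 4 `OC[C@H]1O[C@@H](n2cnc3c(CSc4cccc(Br)c4)ncnc32)[C@H](O)[C@@H]1O` is the next step from compound 3. The change is 3-bromophenyl in place of 2-chlorophenyl on a sulfur. Among the compounds with values here, no measured step changes only this part of the molecule: the three steps in hand all swap the entire group attached to the shared core, and even those whole-group swaps move the number modestly at most. Exchanging one halogen-bearing phenyl for another on the same sulfur is a smaller alteration than any of them, so the expected step of a 1.0-fold higher number from compound 3 to compound 4 (0.00 log units; within the scatter) is small, most likely no change beyond the scatter in either direction. Compound 4 is therefore estimated at 1800 nM, with a range from 700 nM to 4500 nM.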

Compound 4, half-maximal inhibitory concentration: 363 nM
Estimate against measurement, compound 4: 5.0-fold (0.70 log units) above, outside the stated range (below it).
By their numbers in this assay, from the lowest: compound 4; then compounds 3 and 1 (each within the scatter of the next); then compound 2.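

In this assay, the ring on the sulfur turns out to matter: exchanging 2-chlorophenyl for 3-bromophenyl, with the heavy-atom count unchanged, gives a step beyond the scatter (a 4.9-fold lower number from compound 3 to compound 4 (0.69 log units; beyond the scatter)). Earlier, compound 1 and compound 3 could not be told apart despite carrying entirely different groups on the shared core, yet compound 4 stands clearly apart from compound 1 (a 5.8-fold lower number from compound 1 to compound 4 (0.76 log units; beyond the scatter)) and by a large margin from compound 2 (a 17-fold lower number from compound 2 to compound 4 (1.24 log units; beyond the scatter)), so a change confined to the outer ring can do more here than those whole-group swaps did. Nothing available explains why this exchange lowers the number.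

The step changes both the halogen and where it sits on the ring, so the compounds shown cannot say which of the two matters, or whether both do. Also open, on these data alone, is how the number would respond to an unsubstituted phenyl on the sulfur, or to a methoxy group or an amine on that ring in place of the bromine.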